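A few compounds are considered here, and "the series" means these few. Any claim that something is new, unique, unknown or untested is made for them only; others in the source may bear on it.

Measured in a functional assay on HepG2 cells (Homo sapiens) for antiproliferative activity, read by MTT assay, with a stated time of 24 h; a lower number here means a stronger inhibitor, a higher number a weaker inhibitor:
Compound 1, `c1ccc(C2=NN(c3ccc(-c4ccccc4)nn3)C(c3ccccc3)C2)cc1`: 10000 nM
Compound 2, `Fc1ccc(C2CC(c3ccccc3)=NN2c2ccc(-c3ccccc3)nn2)cc1`: 8420 nM
Compound 3, `Fc1ccc(C2CC(c3ccc(Cl)cc3)=NN2c2ccc(-c3ccccc3)nn2)cc1`: 10000 nM

Compound 3 gives the same number as compound 1 at the digits shown, and both sit within the scatter of compound 2, so the three measured compounds are indistinguishable in this assay. Compound 4, `COc1ccc(C2CC(c3ccc(Cl)cc3)=NN2c2ccc(-c3ccccc3)nn2)c(OC)c1`, differs from compound 3 by 2,4-dimethoxyphenyl in place of 4-fluorophenyl on a saturated ring carbon. The two measured steps both changed a group on an aromatic ring: a 1.2-fold lower number from compound 1 to compound 2 (0.07 log units; within the scatter) and a 1.2-fold higher number from compound 2 to compound 3 (0.07 log units; within the scatter), neither beyond the scatter. Going by the values given here, these swaps are smaller than the one into compound 4, yet no measured step here points in any direction, so no change beyond the scatter is expected, a 1.1-fold lower number from compound 3 to compound 4 (0.05 log units; within the scatter). Compound 4 is therefore estimated at 9000 nM, within a range from 4000 nM to 20000 nM.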

Compound 4, half-maximal inhibitory concentration: > 100000 nM
Compound 4 ended at the assay's limit (the forecaster's own chance of this, stated with the estimate: 30%); middle value at least 11-fold (1.04 log units) from the limit.
By their numbers in this assay, from the lowest: compounds 2, 1 and 3 (each within the scatter of the next). At a limit, above all of these: compound 4.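

The earlier swaps of a hydrogen on an aromatic ring all stayed within the scatter, but replacing the whole group on the saturated ring carbon gives the first clear shift in this assay, towards a weaker inhibitor: an at least 10-fold higher number from compound 3 to compound 4 (1.00 log units; beyond the scatter). Compound 4 stands at a limit and not at a number: the limit of > 100000 nM in this assay, at which 1 of the 4 values shown sits. This position therefore does respond to a change of group.

The compounds shown leave open whether one methoxy group alone would give the same step, since both arrive together. As far as these compounds go, how an amine or a longer chain would read at this ring carbon also stays open.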